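From 3-methoxyphenyl to phenyl in compound 3

A few compounds are considered here, and "the series" means these few. Any claim that something is new, unique, unknown or untested is made for them only; others in the source may bear on it.

In a functional assay on MCF7 cells (Homo sapiens) for antiproliferative activity, with a stated time of 96 h (a higher number here means a weaker inhibitor, a lower number a stronger inhibitor), compound 1 (`Cc1cc(=O)oc2cc(OCC(=O)c3ccc(OC(F)(F)F)cc3)ccc12`) gives > 100000 nM as a limit of the assay and not as a number. Compound 2 (`COc1cccc(C(=O)COc2ccc3c(C(F)(F)F)cc(=O)oc3c2)c1`) has no single number to stand on, since its entry reads "not active" (no number reported) in this assay without a measured potency. Compound 3 (`O=C(COc1ccc2c(C(F)(F)F)cc(=O)oc2c1)c1ccccc1`) alters compound 2 in one place: hydrogen in place of methoxy on an aromatic carbon is the whole change, hydrogen in place of methoxy on an aromatic carbon, meta to a large group. Among the compounds with values here, no measured step covers this change, so its size cannot be read from the data. With compound 2 recorded as "not active" (no number reported) in this assay only a small step is expected, in no favoured direction and with weak activity retained. The estimate for compound 3 is 50000 nM with an expected range from 10000 nM to 100000 nM once it is measured.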

Compound 3, half-maximal inhibitory concentration: "not active" (no number reported)
Nothing numeric was reported for compound 3, and the estimate cannot be compared.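

Compound 2 and compound 3 are both recorded as not active, without a number, in this assay, and no step can be read between them. The compounds shown leave open what potency, if any, such structures reach, and the only figure among them is a limit: the limit of > 100000 nM in this assay, at which 1 of the 3 values shown sits.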